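Para substituent swap on the arylpiperazine of compound 3

The source may hold more compounds than are shown below. What is called first, only, known or untested is meant among the compounds shown, and "the series" means these compounds.

Three analogues share one core. Compound 1 `Nc1scc(CN2CCN(c3ccccc3)CC2)c1C(=O)c1ccc(Cl)cc1` gives 1 nM in an assay on CHO cells for displacement of a labelled ligand from adenosine receptor A1 (Homo sapiens); on this read-out higher numbers stand for weaker binding and lower numbers for tighter binding; compound 2 `Nc1scc(CN2CCN(c3ccc(F)cc3)CC2)c1C(=O)c1ccc(Cl)cc1` gives 1 nM; compound 3 `N#Cc1ccc(N2CCN(Cc3csc(N)c3C(=O)c3ccc(Cl)cc3)CC2)cc1` gives 1.1 nM. The steps among them are no change at the digits printed from compound 1 to compound 2 (within the scatter), a 1.1-fold higher number from compound 1 to compound 3 (0.04 log units; within the scatter) and a 1.1-fold higher number from compound 2 to compound 3 (0.04 log units; within the scatter), so compound 3 sits within the scatter of both companions and no ordering can be read from the numbers.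

Compound 4 `Nc1scc(CN2CCN(c3ccc(C(F)(F)F)cc3)CC2)c1C(=O)c1ccc(Cl)cc1` differs from compound 3 by trifluoromethyl in place of cyano on an aromatic carbon. Going by the values given here, the steps that bear on this change are the two that alter the same aromatic carbon: a 1.1-fold higher number from compound 1 to compound 3 (0.04 log units; within the scatter) and a 1.1-fold higher number from compound 2 to compound 3 (0.04 log units; within the scatter). Neither hydrogen, fluoro nor cyano at that carbon moved the number beyond the scatter, which suggests that the site tolerates varied groups, though trifluoromethyl itself has not yet been tested there.

Compound 4 is therefore expected to show a 1.2-fold higher number from compound 3 to compound 4 (0.07 log units; within the scatter), with no change beyond the scatter in this assay. The estimate for compound 4 is 1.3 nM, expected to fall between 0.5 nM and 4 nM.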

Compound 4, dissociation constant: 1 nM
The estimate for compound 4 lay 1.3-fold (0.11 log units) above the measured number; the range from low to high includes it.
By their numbers in this assay, from the lowest: compounds 1, 2, 4 and 3 (each within the scatter of the next).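

Trifluoromethyl now joins hydrogen, fluoro and cyano at this aromatic carbon, and in this assay replacing the nitrile gives a 1.1-fold lower number from compound 3 to compound 4 (0.04 log units; within the scatter). The comparisons with the other two compounds agree, with no change at the digits printed from compound 2 to compound 4 (within the scatter) and no change at the digits printed from compound 1 to compound 4 (within the scatter), so within these four compounds the hydrogen-bond acceptor counted on cyano is not needed to keep the number within the scatter, and a group of four heavy atoms is accepted at this carbon. No measurement shown here accounts for this flat result.

On these data alone, it remains open whether an amine, a carboxylic acid or a longer chain at this carbon would also stay within the scatter. Also open, as far as these compounds go, is whether trifluoromethyl and cyano would remain indistinguishable on another carbon of the ring or in any read-out other than this assay.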